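Notes on aryl replacements in the shared core

This account rests on a few compounds, and the source may have more. Where it says the series, first, only, none or still open, it means among the compounds named here.

Measured so far:
compound 1 `COc1cc(C2=NN(C(C)=O)C(c3cccc(OC)c3OC)O2)cc(OC)c1OC`: 17.5%
compound 2 `COc1cc(C2=NN(C(C)=O)C(c3ccc(F)cc3)O2)cc(OC)c1OC`: 13.3%

In a functional assay on BGC-823 cells (Homo sapiens) for antiproliferative activity, read by MTT assay, tested at 5 uM (on this read-out lower numbers stand for a weaker effect and higher numbers for a stronger effect at the one concentration tested), compound 1 gives 17.5% and compound 2 gives 13.3%. The only measured step, a number 4.2 percentage points lower from compound 1 to compound 2 (within the scatter), is within the scatter, so on the numbers shown compound 2 stands level with compound 1 and the two cannot be ranked.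

Compound 3 `COc1cc(C2=NN(C(C)=O)C(c3ccc(C(F)(F)F)cc3)O2)cc(OC)c1OC` differs from compound 2 by trifluoromethyl in place of fluoro on an aromatic carbon. Among the measured compounds shown here, no measured step exchanges a fluoro for a trifluoromethyl, so nothing bears on this change directly; the one step in hand, a number 4.2 percentage points lower from compound 1 to compound 2 (within the scatter), replaced the whole 4-fluorophenyl by a 2,3-dimethoxyphenyl without moving the read-out beyond the scatter. On that basis the step of a number 1.7 percentage points higher from compound 2 to compound 3 (within the scatter) is expected to stay within the scatter, with no direction claimed. For compound 3 the estimated value is 15%, expected to fall between 4% and 30%.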

Compound 3, a percentage reported as inhibition, at one concentration (the size of the read-out at that concentration, not a potency): 3.4%
Beside the measured number, compound 3's estimate is 11.6 percentage points above it; the whole stated range lies above it.
By their numbers in this assay, from the lowest: compounds 3, 2 and 1 (each within the scatter of the next, the first and the last beyond it).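

In this assay, among the compounds shown here, the aryl group on the saturated ring carbon gives a difference that can be read for the first time: a number 14.1 percentage points lower from compound 1 to compound 3 (beyond the scatter), so 2,3-dimethoxyphenyl and 4-(trifluoromethyl)phenyl can be told apart here, though only modestly. The change on the aromatic carbon alone, a number 9.9 percentage points lower from compound 2 to compound 3 (within the scatter), does not separate 4-fluorophenyl from 4-(trifluoromethyl)phenyl, which leaves compound 2 unranked against either of the other two. Nothing available accounts for the gap between the two aryl groups.

The compounds shown do not tell whether the methoxy groups of compound 1 are what sets it apart from compound 3. They also leave open how an amine or a carboxylic acid on the same aromatic carbon would read at this concentration.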